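Replacing a Hydroxy with Fluoro on a Nucleoside Side Chain

The compounds below may be only part of what the source reports. "The series", "measured", "known", "first", "only" and "open" are said of these compounds alone.

Of the compounds shown here, three sharing one core have been measured in a functional assay on KB cells (Homo sapiens) for cytotoxicity, read by spectrophotometry and crystal violet staining; a higher number here means a weaker inhibitor, a lower number a stronger inhibitor. Compound 1 `N#Cc1c(Cl)n(C2O[C@H](CO)[C@@H](O)[C@H]2O)c2cc(Cl)c(Cl)cc12` gives 35000 nM in this assay, the lowest number of the three. Compound 3 `C[C@H]1OC(n2c(Cl)nc3cc(Cl)c(Cl)cc32)[C@H](O)[C@@H]1O` gives 100000 nM, a higher number that lies beyond the scatter. Compound 2 `CC(=O)c1c(Cl)n([C@H]2C[C@H](O)[C@@H](CO)O2)c2cc(Cl)c(Cl)cc12` gives 400000 nM, the highest number of the set and again beyond the scatter from compound 1. Within these three, compound 1 therefore stands as the strongest inhibitor.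

Compound 4 `N#Cc1c(Cl)n(C2O[C@H](CF)[C@@H](O)[C@H]2O)c2cc(Cl)c(Cl)cc12` has not yet been measured. It differs from compound 1 in a single place: fluoro in place of hydroxy on a saturated chain carbon bound to a saturated ring carbon. Among the compounds with values here, no pair of measured compounds shows this same change, so the data give no direct guide to its size or direction.

For compound 4 the estimate rests on compound 1 alone, and a modest step toward a higher number, beyond the scatter, is expected: a 2.9-fold higher number from compound 1 to compound 4 (0.46 log units; beyond the scatter). Compound 4 is accordingly estimated at 100000 nM, with a likely range from 30000 nM to 400000 nM.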

Compound 4, half-maximal inhibitory concentration: 50000 nM
The estimate for compound 4 lay 2.0-fold (0.30 log units) above the measured number; the measured number falls inside the stated range.
By their numbers in this assay, from the lowest: compounds 1, 4 and 3 (each within the scatter of the next, the first and the last beyond it); then compound 2.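

In this assay, within the data shown here, compound 1 and compound 4 form the first pair in the set that differs at a single place, so the change can now be read directly: fluoro in place of hydroxy on a saturated chain carbon bound to a saturated ring carbon gives a 1.4-fold higher number from compound 1 to compound 4 (0.15 log units; within the scatter). Hydroxymethyl and fluoromethyl therefore cannot be told apart at this position in this read-out, although fluoro counts no hydrogen-bond donor or acceptor where hydroxy counts one of each. Nothing available accounts for how close the two numbers stand.

This single pair leaves open whether the same exchange would read alike on another core. It also leaves open how an amine, a methoxy group or a longer chain would read at this place.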